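Fixing the ring stereocentre in compound 3's ethoxy analogue

The source may report more compounds than this note shows. Statements on the series, on what has been measured and on what is new or still open speak of the compounds shown alone.

Compound 3 `CCOc1ccc(N/N=C2\CCC(C)n3c2ncc(C(=O)O)c3=O)cc1` gives 1.6 umol/kg in a functional assay on the whole organism for inhibition, with Rattus norvegicus as the target (a higher number here means that more compound is needed for the effect, a lower number that less compound is needed), the highest of the three numbers measured; compound 1 `CC1CC/C(=N\Nc2ccc(Br)cc2)c2ncc(C(=O)O)c(=O)n21` gives 0.8 umol/kg, and compound 2 `C[C@@H]1CC/C(=N\Nc2ccc(O)cc2)c2ncc(C(=O)O)c(=O)n21` gives 0.14 umol/kg. Within the data shown here, the only measured single-site step is a 2.0-fold higher number from compound 1 to compound 3 (0.30 log units; within the scatter), which is an ethoxy in place of a bromo on an aromatic carbon and not a stereochemical change. Compound 4 `CCOc1ccc(N/N=C2\CC[C@@H](C)n3c2ncc(C(=O)O)c3=O)cc1` differs from compound 3 as follows: the two compounds have the same atoms and bonds; at least one stereo element is drawn with a configuration in one of them and without one in the other: 1 of 2 stereo elements differ; a stereocentre at a saturated ring carbon is drawn without a configuration in compound 3 and R in compound 4. Among the measured compounds shown here, no measured step separates a compound drawn without configuration at that saturated ring carbon from one drawn with it, so nothing measured bears directly on this change; compound 2, which is drawn with a configuration, and compound 1, which is not, also differ in their aromatic substituent, so their values show only that compound 2 sits lowest. Resolving a stereocentre is expected to move the number at most modestly, and an estimated step of a 1.6-fold lower number from compound 3 to compound 4 (0.20 log units; within the scatter) is expected. Compound 4 is therefore estimated at 1 umol/kg, within a range from 0.35 umol/kg to 3 umol/kg.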

Compound 4, dose for 50% inhibition: 0.2 umol/kg
Compound 4: the middle estimate sits 5.0-fold (0.70 log units) above what was measured, outside the stated range (below it).
By their numbers in this assay, from the lowest: compounds 2 and 4 (each within the scatter of the next); then compounds 1 and 3 (each within the scatter of the next).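

In this assay, among these compounds, drawing the saturated ring carbon as R goes with an 8.0-fold lower number from compound 3 to compound 4 (0.90 log units; beyond the scatter), a step beyond the scatter, whereas no earlier pair isolated this stereocentre. Among the compounds drawn R, ethyl in place of hydrogen on the oxygen on the aromatic ring gives a 1.4-fold higher number from compound 2 to compound 4 (0.15 log units; within the scatter), which lies within the scatter, so this pair does not separate ethoxy from hydroxy at that place. The larger step cannot be read as a comparison of two defined forms, because compound 3 carries no drawn configuration at that carbon: the fact that one of compounds 3 and 4 is drawn with a defined configuration and the other without, at the place where they differ

Going by these compounds, it remains open how the S configuration at that saturated ring carbon compares with R, and whether the bromo compound shows a similar step when drawn R. It is also open how an amine or a longer chain such as propoxy on the aromatic ring would compare with the ethoxy of compound 4.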